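This account rests on a few compounds, and the source may have more. Where it says the series, first, only, none or still open, it means among the compounds named here.

Of the compounds shown here, three built on one shared core have been measured in an assay on cells for displacement of a labelled ligand from corticotropin-releasing factor receptor 1 (Homo sapiens), with a stated time of 100 min; a higher number here means a weaker inhibitor, a lower number a stronger inhibitor. Compound 1 `CCCN(CCC(F)(F)F)Cc1c(C(F)(F)F)nc2n(-c3c(C)cc(C)cc3C)c(Cl)cn12` gives 12 nM, the lowest of the three numbers. Compound 2 `CCN(Cc1c(C(F)(F)F)nc2n(-c3c(C)cc(C)cc3C)c(Cl)cn12)CC1CCC1` gives 16 nM, and the step of a 1.3-fold higher number from compound 1 to compound 2 (0.12 log units; within the scatter) lies within the scatter, so these two cannot be told apart. Within the data shown here, compound 3 `CCCCN(Cc1ccccc1)Cc1c(C(F)(F)F)nc2n(-c3c(C)cc(C)cc3C)c(Cl)cn12` gives 130 nM, a number well beyond the scatter from compound 1, and it is the only measured compound that carries a benzyl group.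

Compound 4 `Cc1cc(C)c(-n2c(Cl)cn3c(CN(C)Cc4ccccc4)c(C(F)(F)F)nc23)c(C)c1` has not yet been measured. It differs from compound 1 in one place: benzyl(methyl)amino in place of propyl(3,3,3-trifluoropropyl)amino on a saturated chain carbon bound to an aromatic carbon. Among the measured compounds shown here, no measured step matches this change exactly. For the measured compounds named here, the only measured step, a 1.3-fold higher number from compound 1 to compound 2 (0.12 log units; within the scatter), exchanges the same amine for one without a benzyl group and stays within the scatter. Going by the values given here, compound 3, the one compound with a benzyl group, gives 130 nM, whereas compound 1 gives 12 nM.

Because compound 3 gives 130 nM, compound 4 is expected to move toward a weaker inhibitor, with an expected step of a 5.0-fold higher number from compound 1 to compound 4 (0.70 log units; beyond the scatter). Compound 4 is therefore estimated at 60 nM, with a range from 20 nM to 200 nM.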

Compound 4, inhibition constant: 160 nM
For compound 4 the middle estimate is 2.7-fold (0.43 log units) below the measured one; measured number inside the range.
By their numbers in this assay, from the lowest: compounds 1 and 2 (each within the scatter of the next); then compounds 3 and 4 (each within the scatter of the next).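

Exchanging propyl(3,3,3-trifluoropropyl)amino for benzyl(methyl)amino on a saturated chain carbon bound to an aromatic carbon brings a clear loss of binding strength, with a 13-fold higher number from compound 1 to compound 4 (1.12 log units; beyond the scatter) as the step, so this position does not treat all amines alike, although the earlier exchange between two amines without a benzyl group stayed within the scatter. The other amine without a benzyl group gives a similar picture, with a 10-fold higher number from compound 2 to compound 4 (1.00 log units; beyond the scatter) as the step, so the two compounds with a benzyl group sit apart from both compounds without one. Once the benzyl group is present, the second chain on the nitrogen makes no readable difference, as butyl gives way to methyl in a 1.2-fold higher number from compound 3 to compound 4 (0.09 log units; within the scatter) and the step stays within the scatter.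

No measurement here explains why the compounds with a benzyl group give the higher numbers. The compounds shown also leave open whether the aromatic ring itself goes with the loss, a question that a cyclohexylmethyl group in place of the benzyl group on the same amine could help to settle.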